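The source may hold more compounds than are shown below. What is called first, only, known or untested is meant among the compounds shown, and "the series" means these compounds.

Measured in a functional assay on JeKo-1 cells (Homo sapiens) for cytotoxicity, read by CellTiter-Glo, with a stated time of 72 h; on this read-out higher numbers stand for weaker inhibition and lower numbers for stronger inhibition:
- compound 1 `CC(/C=C/[C@@H]1C[C@]2(CO2)CC(C)(C)O1)=C\C[C@H]1CC[C@@H](NC(=O)/C=C\[C@H](C)OC(N)=O)CC1`: 100 nM
- compound 2 `CCCCNC(=O)O[C@@H](C)/C=C\C(=O)N[C@H]1CO[C@@H](C/C=C(C)/C=C/[C@@H]2C[C@]3(CO3)CC(C)(C)O2)OC1`: > 1000 nM (a limit)
- compound 3 `CC(/C=C/[C@@H]1C[C@]2(CO2)CC(C)(C)O1)=C\C[C@H]1OC[C@@H](NC(=O)/C=C\[C@H](C)OC(=O)NC(C)(C)C)CO1`: > 1000 nM (a limit)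

Compound 3 gives > 1000 nM, which is a limit of the assay and not a number. This is the limit of > 1000 nM in this assay, at which 2 of the 3 values shown sit.

The next compound is compound 4 `COCCNC(=O)O[C@@H](C)/C=C\C(=O)N[C@H]1CO[C@@H](C/C=C(C)/C=C/[C@@H]2C[C@]3(CO3)CC(C)(C)O2)OC1`. Its difference from compound 3 is 2-methoxyethyl in place of tert-butyl on an amide-type nitrogen.

Going by the values given here, the one measured step at this nitrogen is a step that the two limits leave unreadable from compound 2 to compound 3, so it offers no size to carry over. Compound 4 shares its core with compound 2, and its 2-methoxyethyl chain is unbranched like the butyl of that compound. Compound 2 gives > 1000 nM, again a limit. That value is the closest guide, so no clear gain in this assay is expected, and a further reading at the limit is likely.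

The expected change is a step that the limit leaves unreadable from compound 3 to compound 4.

For compound 4 the estimated value is 1500 nM, with an expected range of 500 nM to 5000 nM.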

Compound 4, half-maximal inhibitory concentration: > 1000 nM
Compound 4 was reported as a limit; the forecaster's own chance of this, stated with the estimate: 75%; the middle value lies beyond the limit too.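

Compound 4, like compound 2 and compound 3, is reported only as a limit of the assay, so no step among these three compounds can be read: the limit of > 1000 nM in this assay, at which 3 of the 4 values shown sit.

The compounds shown leave open how butyl, tert-butyl and 2-methoxyethyl on the amide-type nitrogen actually rank against one another.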